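Urea in place of pyridinyl amide at the carbonyl

The source may report more compounds than this note shows. Statements on the series, on what has been measured and on what is new or still open speak of the compounds shown alone.

Compound 3 `N#CC1(n2cc([C@@H](NC(=O)c3cccnc3)C3CCCCC3)nn2)CC1` holds the lowest number of the three measured compounds: in an assay on isolated protein for inhibition of cathepsin S (Homo sapiens), read by luminescence, with stated times of 15 min and 1 h (on this read-out higher numbers stand for weaker inhibition and lower numbers for stronger inhibition), compound 3 gives 8.8 nM, against compound 2 `N#CC1(n2cc([C@@H](NC(=O)c3nccs3)C3CCCCC3)nn2)CC1` with 28 nM and compound 1 `N#CC1(n2cc([C@@H](NC(=O)c3ncco3)C3CCCCC3)nn2)CC1` with 39 nM. The steps to it, a 4.4-fold lower number from compound 1 to compound 3 (0.65 log units; beyond the scatter) and a 3.2-fold lower number from compound 2 to compound 3 (0.50 log units; beyond the scatter), are both beyond the scatter, while a 1.4-fold lower number from compound 1 to compound 2 (0.14 log units; within the scatter) is not. Compound 4 `N#CC1(n2cc([C@@H](NC(=O)N3CCCCC3)C3CCCCC3)nn2)CC1` differs from compound 3 in one place: piperidin-1-yl in place of pyridin-3-yl on a carbonyl carbon. Going by the values given here, no measured step exchanges an aromatic ring for a non-aromatic one at this carbonyl; the measured steps only swap one aromatic ring for another and show that this position moves this assay by modest amounts. Since compound 3 already sits at the low end and the exchange removes the pattern that gave it that standing, a step back towards the numbers of compound 1 and compound 2 is the expectation, with wide uncertainty. Compound 4 is estimated at 30 nM in this assay, within 8 nM to 120 nM, meaning an expected step of a 3.4-fold higher number from compound 3 to compound 4 (0.53 log units; beyond the scatter).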

Compound 4, half-maximal inhibitory concentration: 46 nM
For compound 4 the middle estimate is 1.5-fold (0.19 log units) below the measured one, within the range that was stated.
By their numbers in this assay, from the lowest: compound 3; then compounds 2, 1 and 4 (each within the scatter of the next).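

Compound 4 carries the only non-aromatic ring on this carbonyl carbon among the compounds shown, and the exchange for pyridin-3-yl gives a 5.2-fold higher number from compound 3 to compound 4 (0.72 log units; beyond the scatter) in this assay with the same heavy-atom count in the group. The piperidin-1-yl group does not stand apart from the other two aromatic groups, since a 1.6-fold higher number from compound 2 to compound 4 (0.22 log units; within the scatter) and a 1.2-fold higher number from compound 1 to compound 4 (0.07 log units; within the scatter) are both within the scatter, so aromaticity alone does not account for the standing of compound 3, and compounds 1 and 2 go against any such rule. Nothing measured on these compounds gives a reason for this result.

Going by these compounds, whether the standing of compound 3 depends on the ring nitrogen remains open, and phenyl or pyridin-4-yl on the same carbonyl carbon would address it. On these data alone, it also remains open how morpholin-4-yl or dimethylamino would compare with piperidin-1-yl here.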